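This account rests on a few compounds, and the source may have more. Where it says the series, first, only, none or still open, it means among the compounds named here.

For the measured compounds named here, compound 2 `COc1ccc(-c2cc3ccccc3nc2/C=C/C(=O)c2ccc(N)cc2)cc1` has the higher of the two numbers so far: in a functional assay on H184B5F5/M10 cells (Homo sapiens) for antiproliferative activity, read by XTT assay, with a stated time of 72 h (on this read-out lower numbers stand for stronger inhibition and higher numbers for weaker inhibition), compound 2 gives 9290 nM, while compound 1 `COc1ccc(-c2cc3ccccc3nc2/C=C/C(=O)c2c(OC)cccc2OC)cc1` gives 4470 nM. Compound 3 `COc1ccc(-c2cc3ccccc3nc2/C=C/C(=O)c2cnc(N)nc2C)cc1` differs from compound 2 only at the group on the carbonyl carbon: 2-amino-4-methylpyrimidin-5-yl in place of 4-aminophenyl on a carbonyl carbon. Going by the values given here, the one measured step that touches this position is a 2.1-fold higher number from compound 1 to compound 2 (0.32 log units; beyond the scatter), and it exchanges a different pair of groups, so it cannot give the direction for compound 3; it only shows that swapping the group on this carbonyl carbon shifted the number modestly. Among the compounds with values here, no measured compound carries an aromatic ring with two hetero atoms at this place. A change of modest size is expected, with no clear direction, and the estimate stays close to compound 2. Compound 3 is estimated at 10000 nM, within 4000 nM to 25000 nM. This estimate means an expected 1.1-fold higher number from compound 2 to compound 3 (0.03 log units; within the scatter).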

Compound 3, half-maximal inhibitory concentration: > 10000 nM
Compound 3: a limit, no number; the forecaster's own chance of this, stated with the estimate: 15%; the middle value sits exactly at the limit.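

In this assay compound 3 gives a limit and not a number: the limit of > 10000 nM in this assay, at which 1 of the 3 values shown sits. Placing 2-amino-4-methylpyrimidin-5-yl on the carbonyl carbon in place of 4-aminophenyl gives an at least 1.0-fold higher number from compound 2 to compound 3 (0.03 log units; that floor lies within the scatter), so the true size of this change stays unknown and the two groups cannot be ranked. In place of 2,6-dimethoxyphenyl, the same group gives an at least 2.2-fold higher number from compound 1 to compound 3 (0.34 log units; beyond the scatter), which shows that an aromatic ring with two hetero atoms at this place reads weaker than the 2,6-dimethoxyphenyl group.

The change from compound 2 swaps ring atoms and adds a methyl group in one step, so the compounds shown cannot separate the two. A 2-aminopyrimidin-5-yl group without the methyl, or a 4-amino-2-methylphenyl group, would pull these two parts of the change apart.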